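The compounds below may be only part of what the source reports. "The series", "measured", "known", "first", "only" and "open" are said of these compounds alone.

Compound 3 `Cc1c(C)c2c(c(C)c1OC/C=C/c1ccccc1)CCC(C)(COc1ccc(/C=C3\SC(=O)NC3=O)cc1)O2` gives the highest of the three numbers in a functional assay on MCF7 cells (Homo sapiens), tested at 5 uM; a higher number here means a weaker effect of the compound at the concentration tested, a lower number a stronger effect: compound 3 reads 65%, compound 2 `CC(C)=CCOc1c(C)c(C)c2c(c1C)CCC(C)(COc1ccc(/C=C3\SC(=O)NC3=O)cc1C)O2` reads 56%, within the scatter of it, and compound 1 `C=CCOc1c(C)c(C)c2c(c1C)CCC(C)(COc1ccc(/C=C3\SC(=O)NC3=O)cc1)O2` reads 42%, beyond the scatter. Compound 4 `CC(C)=CCOc1c(C)c(C)c2c(c1C)CCC(C)(COc1ccc(/C=C3\SC(=O)NC3=O)cc1)O2` differs from compound 3 in one place: 2-methylprop-1-en-1-yl in place of 2-phenylethenyl on a saturated chain carbon bound to an oxygen on an aromatic ring. For the measured compounds named here, the one measured step that bears on this is a number 23 percentage points higher from compound 1 to compound 3 (beyond the scatter), which ran the opposite way, towards a weaker effect. Compound 2, which carries the same 2-methylprop-1-en-1-yl group on a closely related structure, gives 56%. Compound 4 is therefore expected to give back part of that shift, estimated as a number 15 percentage points lower from compound 3 to compound 4 (beyond the scatter), a modest step towards a stronger effect. Compound 4 is estimated at 50%, between 38% and 64%.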

Compound 4, a percentage reported as activity, at one concentration (the size of the read-out at that concentration, not a potency): 21%
Compound 4: the middle estimate sits 29 percentage points above what was measured; measured number outside the range, below it.
By their numbers in this assay, from the lowest: compound 4; then compound 1; then compounds 2 and 3 (each within the scatter of the next).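

At this position, 2-methylprop-1-en-1-yl gives the strongest effect of the four compounds in this assay, compared with 2-phenylethenyl (a number 44 percentage points lower from compound 3 to compound 4 (beyond the scatter)) and with vinyl (a number 21 percentage points lower from compound 1 to compound 4 (beyond the scatter)). The same group also depends heavily on the rest of the molecule, since hydrogen in place of methyl on an aromatic carbon gives a large change (a number 35 percentage points lower from compound 2 to compound 4 (beyond the scatter)). Nothing measured here explains either shift. Going by these compounds, whether a longer chain or an amine at this position would keep or strengthen the effect remains open, and so does whether the methyl change would matter as much with vinyl or 2-phenylethenyl in place.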